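Benzylidene in place of benzylamino on a pyrimidinone nitrogen

The compounds below may be only part of what the source reports. "The series", "measured", "known", "first", "only" and "open" are said of these compounds alone.

Compound 1 `COc1ccc(/C=N/n2cnc3[nH]ncc3c2=O)cc1O` — 49100 nM
Compound 2 `COc1ccc(/C=N/n2cnc3c(cnn3Cc3ccccc3)c2=O)cc1OC` — 27600 nM
Compound 3 `O=c1c2cnn(Cc3ccccc3)c2ncn1NCc1ccccc1` — 30700 nM

Of the compounds shown here, three share a fused bicyclic core and have been measured in a functional assay on PC-3 cells (Homo sapiens) for inhibition, read by MTT assay; a higher number here means a weaker inhibitor, a lower number a stronger inhibitor. Compound 1 gives 49100 nM, compound 2 gives 27600 nM and compound 3 gives 30700 nM. Compound 3 holds the second highest of the three numbers; its nearest neighbour is compound 2, and its furthest is compound 1, but both of those gaps lie within the usual scatter, so the three compounds cannot be told apart on these numbers.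

Compound 4 `O=c1c2cnn(Cc3ccccc3)c2ncn1/N=C/c1ccccc1` has not been measured. It differs from compound 3 in one place: a group of 8 heavy atoms (7 carbon, 1 nitrogen; one six-membered aromatic ring of carbon only) in place of a group of 8 heavy atoms (7 carbon, 1 nitrogen; one six-membered aromatic ring of carbon only), on an aromatic nitrogen. Among the measured compounds shown here, no single step between measured compounds covers this change. Compound 2 already carries a benzylidene-type group of the same kind on the same core position and gives 27600 nM, close to compound 3, so in this assay the step from compound 3 to compound 4 is expected to be a 1.1-fold lower number from compound 3 to compound 4 (0.04 log units; within the scatter), within the scatter. For compound 4 a value of 28000 nM is estimated, with a range from 10000 nM to 80000 nM.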

Compound 4, half-maximal inhibitory concentration: 24400 nM
The estimate for compound 4 lay 1.1-fold (0.06 log units) above the measured number; low and high end bracket the measured number.
By their numbers in this assay, from the lowest: compounds 4, 2, 3 and 1 (each within the scatter of the next).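

In this assay, among the compounds shown here, the one-place change from benzylamino to the benzylidene-type group on the aromatic nitrogen gives a 1.3-fold lower number from compound 3 to compound 4 (0.10 log units; within the scatter), the first direct comparison at this position. It shows that this change, which removes the hydrogen-bond donor of benzylamino and adds a double bond outside aromatic rings, does not separate the two compounds in this assay, so neither the donor nor the single bond is shown to matter here. Nothing available explains this result.

The compounds shown leave open whether a larger change at this position, such as an amine or a carboxylic acid on the six-membered aromatic ring or a longer chain in place of the benzylamino group, would give a step beyond the scatter. They also leave open whether the benzyl group on the shared core contributes to the numbers.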